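This account rests on a few compounds, and the source may have more. Where it says the series, first, only, none or still open, it means among the compounds named here.

Measured compounds in a functional assay on the whole organism for antagonist activity, with Mus musculus as the target; a lower number here means that less compound is needed, a higher number that more compound is needed for the effect:
- compound 1 `CCCCCCCN1CCC(C(=O)Nc2cc(Cl)c(N)cc2OC)CC1` gives > 10 mg/kg, a limit of the assay and not a number.
- compound 2 `CCCCN1CCC(C(=O)Nc2cc(Cl)c(N)cc2OC)CC1` gives > 10 mg/kg, likewise only a limit.
- compound 3 `COc1cc(N)c(Cl)cc1NC(=O)C1CCN(Cc2ccc(F)cc2)CC1` gives 0.6 mg/kg.

Compound 2 thus stands only at a limit in this assay; among the values shown, one further sits at the same limit (the limit of > 10 mg/kg in this assay, at which 2 of the 3 values shown sit). The unmeasured compound 4 `COc1cc(N)c(Cl)cc1NC(=O)C1CCN(Cc2cccc(Cl)c2)CC1` differs from compound 2 in one place: 3-chlorophenyl in place of propyl on a saturated chain carbon bound to an amine nitrogen in a ring. Among the measured compounds shown here, two measured steps bear on this change. Putting the 4-fluorophenyl at the same place gave an at least 16-fold lower number from compound 2 to compound 3 (1.22 log units; beyond the scatter), and from the longer chain an at least 16-fold lower number from compound 1 to compound 3 (1.22 log units; beyond the scatter). The step between the two chain lengths, a step that the two limits leave unreadable from compound 1 to compound 2, cannot be read from two limits. Compound 4 also carries an aromatic ring at that place, so a large lowering of the number in this assay is expected for compound 4, with compound 3 and its 0.6 mg/kg as the anchor. Compound 4 is therefore estimated at 1 mg/kg, with a range from 0.3 mg/kg to 3.5 mg/kg. This amounts to an expected step of an at least 10-fold lower number from compound 2 to compound 4 (1.00 log units; beyond the scatter).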

Compound 4, dose for half-maximal effect: > 4 mg/kg
Compound 4 gave a limit, no number (the forecaster's own chance of this, stated with the estimate: 12%); middle value at least 4.0-fold (0.60 log units) away from the limit.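

In this assay, an aromatic ring on a saturated chain carbon bound to an amine nitrogen in a ring does not by itself secure a low number: 3-chlorophenyl in place of 4-fluorophenyl gives an at least 6.6-fold higher number from compound 3 to compound 4 (0.82 log units; beyond the scatter) at this place. Compound 4 is held only as a limit of the assay, not a number: the limit of > 4 mg/kg in this assay, at which 1 of the 4 values shown sits. The steps from compound 1 to compound 4 and from compound 2 to compound 4 join two limits and cannot be read.

The two aromatic groups differ in both halogen and ring position, so 4-chlorophenyl or 3-fluorophenyl at this place would be needed to separate the two. Unsubstituted phenyl would show what the ring gives without any halogen.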